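Replacing an aromatic ring with methoxy on a carbonyl carbon

This account rests on a few compounds, and the source may have more. Where it says the series, first, only, none or still open, it means among the compounds named here.

Compound 3 `O=C(c1cccc(F)c1)N(/N=N/c1ccc([N+](=O)[O-])cc1Cl)c1ccc([N+](=O)[O-])cc1Cl` is one of three closely related molecules tested in a functional assay on HeLa cells (Homo sapiens) for cytotoxicity, read by MTT assay, with a stated time of 72 h; a lower number here means a stronger inhibitor, a higher number a weaker inhibitor. In this assay compound 3 gives 2500 nM, the second highest of the three numbers. Compound 1 `O=[N+]([O-])c1ccc(/N=N/Nc2ccc([N+](=O)[O-])cc2Cl)c(Cl)c1` carries a hydrogen where compound 3 carries a (3-fluorophenyl)carbonyl, and compound 1 gives 3010 nM; the step of a 1.2-fold lower number from compound 1 to compound 3 (0.08 log units; within the scatter) leaves the two within the scatter of each other. Compound 2 `O=C(c1ccc(C(F)(F)F)cc1)N(/N=N/c1ccc([N+](=O)[O-])cc1Cl)c1ccc([N+](=O)[O-])cc1Cl` carries a 4-(trifluoromethyl)phenyl on the carbonyl carbon and gives 1060 nM; the step of a 2.4-fold higher number from compound 2 to compound 3 (0.37 log units; beyond the scatter) is modest but beyond the scatter.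

Compound 4 `COC(=O)N(/N=N/c1ccc([N+](=O)[O-])cc1Cl)c1ccc([N+](=O)[O-])cc1Cl` differs from compound 3 by methoxy in place of 3-fluorophenyl on a carbonyl carbon. Going by the values given here, two measured steps bear on this. The step from compound 1 to compound 3 shows that adding the whole (3-fluorophenyl)carbonyl changed little, and the step from compound 2 to compound 3 shows that exchanging one aromatic ring for another on the carbonyl carbon moved the number only modestly. Removing the ring and leaving a methoxycarbonyl is therefore expected to give a number close to those of compound 1 and compound 3, a step of a 1.2-fold higher number from compound 3 to compound 4 (0.08 log units; within the scatter), not clearly beyond the scatter. Compound 4 is thus estimated at 3000 nM, with a range from 1200 nM to 8000 nM.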

Compound 4, half-maximal inhibitory concentration: 980 nM
Compound 4: the middle estimate sits 3.1-fold (0.49 log units) above what was measured; the measured number lies below the stated range.
By their numbers in this assay, from the lowest: compounds 4 and 2 (each within the scatter of the next); then compounds 3 and 1 (each within the scatter of the next).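

In this assay the step of a 2.6-fold lower number from compound 3 to compound 4 (0.41 log units; beyond the scatter) comes from methoxy in place of 3-fluorophenyl on the carbonyl carbon, which shows that an aromatic ring at this position is not needed to reach the lower numbers seen in this small set. The step of a 1.1-fold lower number from compound 2 to compound 4 (0.03 log units; within the scatter), from methoxy in place of 4-(trifluoromethyl)phenyl, leaves those two compounds indistinguishable, so having or lacking a ring does not by itself set the number, and compound 3 goes against any simple rule that a ring or its absence decides the outcome. The step of a 3.1-fold lower number from compound 1 to compound 4 (0.49 log units; beyond the scatter), from methoxycarbonyl in place of hydrogen on the nitrogen, also shows that a group added at this nitrogen can change the number, which the (3-fluorophenyl)carbonyl of compound 3 did not show.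

No measurement among these compounds explains why these groups give different numbers. Going by these compounds, it also remains open whether a longer chain such as butoxy, or an amine on the carbonyl carbon, would give a number like that of compound 4 or one closer to that of compound 1.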